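Permeability of a Shared Core with Varied Anilines

The compounds below may be only part of what the source reports. "The series", "measured", "known", "first", "only" and "open" are said of these compounds alone.

Measured compounds in an ADME assay on Caco-2 cells (Homo sapiens) for permeability, in the apical to basolateral direction; on this read-out higher numbers stand for higher permeability and lower numbers for lower permeability:
Compound 1 `CNC(=O)c1cc(Oc2ccc3nc(Nc4cccc(C(C)(C)C)c4)ncc3c2)ccn1`; compound 1 gives < 1 10^-6 cm/s, a limit of the assay.
Compound 2 `CNC(=O)c1cc(Oc2ccc3nc(Nc4ccccc4Br)ncc3c2)ccn1`; compound 2 gives < 1 10^-6 cm/s, again a limit.
Compound 3 `CNC(=O)c1cc(Oc2ccc3nc(Nc4cccc(C(C)C)c4)ncc3c2)ccn1`; compound 3 gives < 1 10^-6 cm/s, also a limit.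

Compound 2 therefore stands at the limit of this assay rather than at a number, and the two further values shown are limits as well. The three measured steps, a step that the two limits leave unreadable from compound 1 to compound 2, a step that the two limits leave unreadable from compound 1 to compound 3 and a step that the two limits leave unreadable from compound 2 to compound 3, all run between limits, so none of them yields a readable size, a point summed up by the limit of < 1 10^-6 cm/s in this assay, at which 3 of the 3 values shown sit.

The unmeasured compound 4 `CNC(=O)c1cc(Oc2ccc3nc(Nc4ccc(C(F)(F)F)cc4)ncc3c2)ccn1` differs from compound 2 in one place: 4-(trifluoromethyl)phenyl in place of 2-bromophenyl on a nitrogen on an aromatic ring. Among the measured compounds shown here, the measured steps bear on this change only in that every variation of the group on that nitrogen so far has left the value at the limit; no step gives a size or a direction to carry over.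

The account expects no step beyond the scatter; the estimated step is a step that the limit leaves unreadable from compound 2 to compound 4. The estimate for compound 4 in this assay is 0.7 10^-6 cm/s, within a range from 0.2 10^-6 cm/s to 2.5 10^-6 cm/s.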

Compound 4, apparent permeability: < 1 10^-6 cm/s
Compound 4: a limit, no number; the forecaster's own chance of this, stated with the estimate: 65%; the middle value does not contradict the limit.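

Compound 4 also gives only a limit in this assay and not a number, so its steps from compound 1, compound 2 and compound 3 cannot be read: the limit of < 1 10^-6 cm/s in this assay, at which 4 of the 4 values shown sit. The compounds shown leave open how these four compare with one another, and whether any group on that nitrogen gives a readable number.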